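Swapping the Ring on the Aromatic Nitrogen of a Shared Core

The compounds below may be only part of what the source reports. "The series", "measured", "known", "first", "only" and "open" are said of these compounds alone.

Compound 1 `CN(C)C(=O)CN1CCC(c2cc3c(-c4ccc(=O)n(C5CCC5)c4)ccnc3[nH]2)CC1` gives 5.8 uL/min in an ADME assay on cells (Hepatocyte, Rattus norvegicus) for metabolic stability; a higher number here means faster removal of the compound, a lower number slower removal.
Compound 2 `CC(C)n1cc(-c2ccnc3[nH]c(C4CCN(CC(=O)N5CCCCC5)CC4)cc23)ccc1=O` gives 26 uL/min in this assay.
Compound 3 `CC(C)n1cc(-c2ccnc3[nH]c(C4CCN(CC(=O)N5CCCC5)CC4)cc23)ccc1=O` gives 5.4 uL/min in this assay.

All three measured compounds share one core. Compound 1 stands second highest of the three numbers. Its nearest neighbour is compound 3, whose value lies within the usual scatter of it, so no order between those two can be read from the data. Compound 2 lies beyond the scatter above both of them.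

Among the compounds with values here, the only single-point step among the measured compounds is a 4.8-fold lower number from compound 2 to compound 3 (0.68 log units; beyond the scatter). It concerns the ring on the carbonyl carbon, and it shows that exchanging one such ring for another can shift the number by a modest amount.

Compound 4 `CN(C)C(=O)CN1CCC(c2cc3c(-c4ccc(=O)n(CC5CCOCC5)c4)ccnc3[nH]2)CC1` has not yet been measured. It differs from compound 1 in a single place: (oxan-4-yl)methyl in place of cyclobutyl on an aromatic nitrogen. Within the data shown here, no measured step touches this aromatic nitrogen, so the measured step gives a sense of how large a single ring exchange can be, but not of its direction here. A step of modest size in either direction, or none beyond the scatter, is therefore expected in this assay. The estimate for compound 4 is 8 uL/min, with a range from 3 uL/min to 22 uL/min, which corresponds to an expected step of a 1.4-fold higher number from compound 1 to compound 4 (0.14 log units; within the scatter).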

Compound 4, intrinsic clearance in a liver preparation (reported as CLH), per the amount of preparation that the assay uses: 1.8 uL/min
Compound 4: the middle estimate sits 4.4-fold (0.65 log units) above what was measured; the measured number lies below the stated range.
By their numbers in this assay, from the lowest: compound 4; then compounds 3 and 1 (each within the scatter of the next); then compound 2.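

The aromatic nitrogen turns out to be a place where the number responds: in this assay, (oxan-4-yl)methyl in place of cyclobutyl gives a 3.2-fold lower number from compound 1 to compound 4 (0.51 log units; beyond the scatter). The earlier step concerned only the ring on the carbonyl carbon, so it gave no direction for this position, and this step now gives one for this single exchange. The change brings in a six-membered ring with 1 hetero atom and raises the group from 4 heavy atoms to 7, but nothing here ties the lower number to any one of these differences.

The exchange alters ring size, the oxygen and the attachment all at once, so a cyclohexylmethyl group, which keeps the chain and ring but has only carbon, or an oxan-4-yl ring placed directly on the nitrogen, would be needed to pull these apart. As far as these compounds go, it also remains open how an amine or a longer chain on this nitrogen would behave, and whether the same exchange would shift the number in the same direction with a pyrrolidin-1-yl or piperidin-1-yl ring on the carbonyl carbon.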